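Thiophen-2-yl swapped for ethynyl

The source may hold more compounds than are shown below. What is called first, only, known or untested is meant among the compounds shown, and "the series" means these compounds.

Compound 1 `C#Cc1cn([C@@H]2O[C@H](CO)[C@@H](O)[C@H]2O)c2ncnc(OC)c12` gives 190 nM
Compound 2 `CNc1ncnc2c1c(-c1cccs1)cn2[C@@H]1O[C@H](CO)[C@@H](O)[C@H]1O` gives > 20000 nM

In a functional assay on HL-60 cells (Homo sapiens) for antiproliferative activity, read by XTT assay, with a stated time of 72 h (a higher number here means a weaker inhibitor, a lower number a stronger inhibitor), compound 2 stands at > 20000 nM as a limit of the assay, not as a number. Going by the values given here, compound 3 `C#Cc1cn([C@@H]2O[C@H](CO)[C@@H](O)[C@H]2O)c2ncnc(NC)c12` differs from it in one place, with ethynyl in place of thiophen-2-yl on an aromatic carbon as the only change. Among the compounds with values here, no measured pair shows this change, so a large drop in the number in this assay is only an expectation, meaning a stronger inhibitor. It rests on compound 1, also an ethynyl compound, at 190 nM in that test. The estimated value for compound 3 is 400 nM within an expected range of 60 nM to 5000 nM overall. This expectation amounts to an at least 50-fold lower number from compound 2 to compound 3 (1.69 log units; beyond the scatter) as an estimated step.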

Compound 3, half-maximal inhibitory concentration: 9060 nM
Estimate against measurement, compound 3: 23-fold (1.36 log units) below; the measured number lies above the stated range.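

In this assay, ethynyl in place of thiophen-2-yl on this aromatic carbon gives an at least 2.2-fold lower number from compound 2 to compound 3 (0.34 log units; beyond the scatter). Compound 2 stands at a limit and not at a number, so this step shows only a minimum size: the limit of > 20000 nM in this assay, at which 1 of the 3 values shown sits.

With ethynyl kept, methylamino in place of methoxy gives a 48-fold higher number from compound 1 to compound 3 (1.68 log units; beyond the scatter), so ethynyl alone does not secure a low number, and the other group on the shared core matters too.

Still open, going by these compounds, is how a methyl, a bromine or a phenyl would fare on this carbon. Also open, on these data alone, is whether thiophen-2-yl paired with methoxy would give a measurable number.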